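This account rests on a few compounds, and the source may have more. Where it says the series, first, only, none or still open, it means among the compounds named here.

Measured in a functional assay on HT-29 cells (Homo sapiens) for inhibition, read by MTT assay, with a stated time of 48 h; on this read-out higher numbers stand for weaker inhibition and lower numbers for stronger inhibition:
- Compound 1 `CCSc1nnc(-c2cc(OC)c(OC)c(OC)c2)n1-c1ccc(N(C)C)cc1`: > 60000 nM (a limit)
- Compound 2 `COc1cc(-c2nnc(SCC(=O)c3ccccc3)n2-c2ccc(N(C)C)cc2)cc(OC)c1OC`: 45200 nM
- Compound 3 `COc1ccc(C(=O)CSc2nnc(-c3cc(OC)c(OC)c(OC)c3)n2-c2ccc(N(C)C)cc2)cc1`: 64000 nM

The entry for compound 1 is a limit of the assay and not a number. Compound 3 at 64000 nM stands within the scatter of compound 2 at 45200 nM, so the two true numbers in the series do not separate.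

The next compound is compound 4 `COc1cc(-c2nnc(SCC(=O)c3ccc(F)cc3)n2-c2ccc(N(C)C)cc2)cc(OC)c1OC`. The change is fluoro in place of methoxy on an aromatic carbon, para to a large group.

The nearest measured evidence is the change on that same aromatic carbon, a 1.4-fold higher number from compound 2 to compound 3 (0.15 log units; within the scatter). The two steps that replace methyl on the saturated chain carbon bound to the sulfur are less informative: an at least 1.3-fold lower number from compound 1 to compound 2 (0.12 log units; that floor lies within the scatter) and a step that the limit leaves unreadable from compound 1 to compound 3. Among the measured compounds shown here, neither gives a size beyond the scatter, and no fluoro compound has been measured. No step beyond the scatter is therefore expected in this assay, and no direction can be favoured.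

The step estimated here is a 1.3-fold lower number from compound 3 to compound 4 (0.11 log units; within the scatter). For compound 4 the expected value is 50000 nM, with an estimated range from 25000 nM to 95000 nM.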

Compound 4, half-maximal inhibitory concentration: 78100 nM
Compound 4: the middle estimate sits 1.6-fold (0.19 log units) below what was measured, within the range that was stated.
By their numbers in this assay, from the lowest: compounds 2, 3 and 4 (each within the scatter of the next).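

In this assay, the new fluoro group at this place gives a 1.2-fold higher number from compound 3 to compound 4 (0.09 log units; within the scatter) when it replaces methoxy, and a 1.7-fold higher number from compound 2 to compound 4 (0.24 log units; within the scatter) when it replaces hydrogen. Hydrogen, methoxy and fluoro on this aromatic carbon, para to a large group, therefore do not separate in this read-out, so compound 2, compound 3 and compound 4 form one group within the scatter and the change from 4-methoxyphenyl to 4-fluorophenyl shows no readable effect. The step from compound 1 to compound 4 cannot be read, like the other steps from compound 1, which holds a limit and not a number: the limit of > 60000 nM in this assay, at which 1 of the 4 values shown sits.

Going by these compounds, what an amine or a carboxylic acid on this same aromatic carbon would give remains open, as does whether any group there can move the number beyond the scatter. Also open, on these data alone, is whether a longer chain on the sulfur, in place of the chains carrying the phenyl ketones, would give a readable step from the shared core.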